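The source may report more compounds than this note shows. Statements on the series, on what has been measured and on what is new or still open speak of the compounds shown alone.

Compound 1, `O=C(O)c1ccc(C(=O)/C(=C\c2ccc(Br)c([N+](=O)[O-])c2)SCc2ccc(Cl)cc2)cc1`: < 1000 nM
Compound 2, `O=C(O)c1ccc(C(=O)/C(=C\c2ccc(Br)c([N+](=O)[O-])c2)SCc2ccc(Cl)cc2Cl)cc1`: 1000 nM
Compound 3, `CN(C)c1ccc(/C=C(/SCc2ccc(Cl)cc2)C(=O)c2ccc(Cl)cc2)cc1`: > 100000 nM

Of the compounds shown here, three have been measured in a functional assay on DU-145 cells (Homo sapiens) for inhibition, read by trypan blue exclusion, with a stated time of 96 h; on this read-out lower numbers stand for stronger inhibition of growth and higher numbers for weaker inhibition of growth. For compound 1 `O=C(O)c1ccc(C(=O)/C(=C\c2ccc(Br)c([N+](=O)[O-])c2)SCc2ccc(Cl)cc2)cc1` this assay reports only a limit, < 1000 nM. Compound 2 `O=C(O)c1ccc(C(=O)/C(=C\c2ccc(Br)c([N+](=O)[O-])c2)SCc2ccc(Cl)cc2Cl)cc1` carries the change chloro in place of hydrogen on an aromatic carbon and gives 1000 nM in this assay. The step of a number no lower from compound 1 to compound 2 (the limit leaves the size open) cannot be sized because the limit of < 1000 nM in this assay, at which 1 of the 3 values shown sits, leaves it open.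

Compound 3 `CN(C)c1ccc(/C=C(/SCc2ccc(Cl)cc2)C(=O)c2ccc(Cl)cc2)cc1` has a different core; the difference between the core of compound 1 and the core of compound 3 is not broken down here. For compound 3 this assay reports only a limit, > 100000 nM. That value sits at the limit of > 100000 nM in this assay, at which 1 of the 3 values shown sits.

Compound 4 `CN(C)c1ccc(/C=C(/SCc2ccc(Cl)c(Cl)c2)C(=O)c2ccc(Cl)cc2)cc1` has not yet been measured. It differs from compound 3 by chloro in place of hydrogen on an aromatic carbon. This is the same kind of change as that made from compound 1 to compound 2, but not the same: in compound 4 the entering chloro sits ortho to a chloro group and meta to a large group, whereas in compound 2 it sits ortho to a large group and meta to a chloro group.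

Because compound 3 sits at the limit of > 100000 nM in this assay, at which 1 of the 3 values shown sits, the step expected for compound 4 in this assay, a number no higher from compound 3 to compound 4 (the limit leaves the size open), is small, with the result most likely again a limit. Compound 4 is estimated at 100000 nM, between 30000 nM and 300000 nM.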

Compound 4, concentration for 50% growth inhibition: 50000 nM
Beside the measured number, compound 4's estimate is 2.0-fold (0.30 log units) above it, and the stated range covers the measured number.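

In this assay, chloro in place of hydrogen on an aromatic carbon, which turns 4-chlorobenzyl into 3,4-dichlorobenzyl, gives an at least 2.0-fold lower number from compound 3 to compound 4 (0.30 log units; that floor lies within the scatter). Compound 3 has only a limit, > 100000 nM, so this step gives a floor and not a size, and that floor offers no firm evidence of a gain on this core. The earlier step on the core of compound 1 cannot be read in size either, so the data show neither that the change carries over between the two cores nor that it behaves differently on them, and the entering chloro does not stand in the same place on the two cores: the same change on two cores in this assay, a number no lower (the limit leaves the size open) from compound 1 to compound 2 and an at least 2.0-fold lower number (0.30 log units; that floor lies within the scatter) from compound 3 to compound 4; the limit leaves it open whether they differ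

The compounds shown leave open what chloro does at one and the same place on both cores, as no pair here offers that comparison, and a pair on each core with values that are not limits would be needed to size the two steps. Also open, on these data alone, is whether a fluoro, a methyl or a methoxy group in place of the entering chloro would give a step of like size on either core.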